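Amide nitrogen substituent exchange in the shared core series

A few compounds are considered here, and "the series" means these few. Any claim that something is new, unique, unknown or untested is made for them only; others in the source may bear on it.

Compound 1 `CCN(CC)CCNC(=O)c1ccc(C(CC)(CC)c2ccc(OCC(=O)C(C)(C)C)c(C)c2)n1CC` carries a 2-(diethylamino)ethyl group on the amide-type nitrogen of the shared core. For the measured compounds named here, in an assay on HL-60 cells for agonist activity at vitamin D3 receptor (Homo sapiens), read by microscopy, with a stated time of 96 h (a higher number here means that more compound is needed for the effect, a lower number that less compound is needed), compound 1 gives 91 nM, the lowest of the three numbers so far. Compound 2 `CCn1c(C(=O)N(CCC#N)CCC#N)ccc1C(CC)(CC)c1ccc(OCC(O)C(C)(C)C)c(C)c1` gives 97 nM in this assay, within the scatter of compound 1, so no order can be read between these two. Compound 3 `C#CCCOC(=O)c1ccc(C(CC)(CC)c2ccc(OCC(O)C(C)(C)C)c(C)c2)n1CC`, in which an ester replaces the amide, gives 1030 nM; the step of an 11-fold higher number from compound 2 to compound 3 (1.03 log units; beyond the scatter) is the only one in the set and is large.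

Compound 4 `CCOc1ccc(NC(=O)c2ccc(C(CC)(CC)c3ccc(OCC(=O)C(C)(C)C)c(C)c3)n2CC)cc1` differs from compound 1 by 4-ethoxyphenyl in place of 2-(diethylamino)ethyl on an amide-type nitrogen. Going by the values given here, no measured step reproduces this change. The step of an 11-fold higher number from compound 2 to compound 3 (1.03 log units; beyond the scatter) concerns the carbonyl carbon, not the amide nitrogen, and only shows that losing the amide costs much; compound 4 keeps the amide. The values of compound 1 and compound 2 show that two quite different nitrogen substituents give numbers within the scatter of each other, which weakly suggests tolerance at this position, though an aromatic ring has not been tried here.

The expected step is a 1.6-fold higher number from compound 1 to compound 4 (0.22 log units; within the scatter), a modest change with wide uncertainty. Compound 4 is therefore estimated at 150 nM in this assay, within a range of 40 nM to 600 nM.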

Compound 4, half-maximal effective concentration: > 50000 nM
Compound 4: only a limit was reported; the forecaster's own chance of this, stated with the estimate: 5%; middle value at least 330-fold (2.52 log units) from the limit.
By their numbers in this assay, from the lowest: compounds 1 and 2 (each within the scatter of the next); then compound 3. At a limit, above all of these: compound 4.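

Compound 4 stands in this assay only as a limit, not as a number: the limit of > 50000 nM in this assay, at which 1 of the 4 values shown sits.

For the compounds shown here, with the amide kept, 4-ethoxyphenyl in place of 2-(diethylamino)ethyl on the amide-type nitrogen gives an at least 540-fold higher number from compound 1 to compound 4 (2.73 log units; beyond the scatter), so this position does not accept every substituent, which the earlier compounds gave no sign of. A change on this nitrogen alone is therefore enough for a large step, and it reaches further than the step seen when the amide gives way to an ester, an 11-fold higher number from compound 2 to compound 3 (1.03 log units; beyond the scatter).

The compounds shown leave open whether the step follows from the aromatic ring itself, from the ethoxy group on it, or from the departure of the diethylamino group from the chain. Going by these compounds, an unsubstituted phenyl, a benzyl group or a 2-(piperidin-1-yl)ethyl chain on the same nitrogen of the core of compound 1 would separate these readings, and it also remains open how far a plain alkyl chain without an amine would carry.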